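The source may hold more compounds than are shown below. What is called first, only, known or untested is meant among the compounds shown, and "the series" means these compounds.

Measured compounds in a functional assay on Jurkat cells (Homo sapiens) for antiproliferative activity, read by MTT assay, with a stated time of 72 h; a lower number here means a stronger inhibitor, a higher number a weaker inhibitor:
- compound 1, `COc1cc(-n2ncnc2-c2ccc(F)cc2)cc(OC)c1OC`: compound 1 gives > 10000 nM, which is a limit of the assay.
- compound 2, `COc1cc(-n2ncnc2-c2ccc(C)cc2)cc(OC)c1OC`: compound 2 gives 300 nM.
- compound 3, `COc1cc(-n2ncnc2-c2ccccc2)cc(OC)c1OC`: compound 3 gives > 10000 nM, which is a limit of the assay.

Compound 3 thus stands at the limit of this assay, where two of the three measured values sit (the limit of > 10000 nM in this assay, at which 2 of the 3 values shown sit). Of the three, only compound 2 yields a number. The step of an at least 33-fold higher number from compound 2 to compound 3 (1.52 log units; beyond the scatter) is large, and the step of an at least 33-fold lower number from compound 1 to compound 2 (1.52 log units; beyond the scatter) is large in the opposite sense, while the step that the two limits leave unreadable from compound 1 to compound 3 cannot be read, since both ends are limits.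

Compound 4, `COc1cc(-n2ncnc2-c2ccc(Cl)c(Cl)c2)cc(OC)c1OC`, differs from compound 3 in one place: 3,4-dichlorophenyl in place of phenyl on an aromatic carbon. Within the data shown here, no measured step covers this change. The nearest evidence is that a fluoro group on the same aromatic ring left compound 1 at the limit, whereas only a methyl group, in compound 2, brought the value down. The account therefore expects compound 4 to stay near the limit, with a step of an at least 1.6-fold lower number from compound 3 to compound 4 (0.22 log units; that floor lies within the scatter) that is not expected to be readable beyond the scatter. The estimate for compound 4 is 6000 nM, within a range from 1500 nM to 20000 nM.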

Compound 4, half-maximal inhibitory concentration: > 10000 nM
Compound 4: a limit, no number; the forecaster's own chance of this, stated with the estimate: 50%; middle value at least 1.6-fold (0.22 log units) from the limit.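

In this assay, the 3,4-dichlorophenyl group of compound 4 joins the phenyl group of compound 3 and the 4-fluorophenyl group of compound 1 at a limit, so three of the four groups at this position now give no number: the limit of > 10000 nM in this assay, at which 3 of the 4 values shown sit. With 3,4-dichlorophenyl in place of 4-methylphenyl there is an at least 33-fold higher number from compound 2 to compound 4 (1.52 log units; beyond the scatter), which shows that the value of compound 2 does not carry over to a ring with two chlorine atoms; among these compounds only the 4-methylphenyl group gives a number, and compounds 1 and 4 go against any reading that a substituent on this ring is enough in itself. The steps from compound 3 to compound 4 and from compound 1 to compound 4 cannot be read, since both ends of each are limits, so these three compounds cannot be ranked against one another.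

The compounds shown leave open whether a number here depends on the methyl group itself, or whether an ethyl or a methoxy group on the same ring would also give one. They also leave open whether a single chlorine, as in 4-chlorophenyl, would follow compound 2 or compound 4.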